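The source may hold more compounds than are shown below. What is called first, only, known or untested is meant among the compounds shown, and "the series" means these compounds.

Measured compounds and their values:

Compound 1, `Cc1ccc(S(=O)(=O)n2cc(/C=N\c3ccc(N4CCOCC4=O)cc3)c3ccccc32)cc1`, gives 56% in an ADME assay on BV-2 cells (Mus musculus) for cytotoxicity, read by MTT assay, with a stated time of 48 h, tested at 60 uM; a higher number here means a weaker effect of the compound at the concentration tested, a lower number a stronger effect.
Compound 2, `O=C1COCCN1c1ccc(/N=C\c2cn(C(=O)c3ccccc3)c3ccccc23)cc1`, gives 57.5% in this assay.
Compound 3, `O=C1COCCN1c1ccc(/N=C\c2cn(C(=O)c3ccc(Cl)cc3)c3ccccc23)cc1`, gives 84.2% in this assay.

Compound 3 stands highest of the three numbers. The nearest value belongs to compound 2, a number 26.7 percentage points higher from compound 2 to compound 3 (beyond the scatter), and the furthest to compound 1, a number 28.2 percentage points higher from compound 1 to compound 3 (beyond the scatter). Between compound 1 and compound 2 the difference is small, a number 1.5 percentage points higher from compound 1 to compound 2 (within the scatter).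

Compound 4, `O=C1COCCN1c1ccc(/N=C\c2cn(Cc3ccccc3)c3ccccc23)cc1`, has not yet been measured. It differs from compound 3 in one place: benzyl in place of (4-chlorophenyl)carbonyl on an aromatic nitrogen. For the measured compounds named here, two measured steps bear on this change. The step from compound 2 to compound 3, a number 26.7 percentage points higher from compound 2 to compound 3 (beyond the scatter), shows that taking the chloro away again can be expected to lower the number by a modest amount, while the swap of one group for another on the aromatic nitrogen, a number 1.5 percentage points higher from compound 1 to compound 2 (within the scatter), left the number within the scatter. The expected step is therefore a modest fall, a number 24.2 percentage points lower from compound 3 to compound 4 (beyond the scatter), back towards the region of compound 1 and compound 2. Compound 4 is estimated at 60%, within a range from 40% to 85%.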

Compound 4, a percentage reported as activity, at one concentration (the size of the read-out at that concentration, not a potency): 65%
Compound 4: middle estimate off by 5 percentage points, on the low side; the range from low to high includes it.
By their numbers in this assay, from the lowest: compounds 1, 2 and 4 (each within the scatter of the next); then compound 3.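

Benzyl on the aromatic nitrogen, joined through a plain carbon instead of a carbonyl or a sulfonyl, leaves the number in this assay within the scatter of the two other groups that lack a chloro, with a number 7.5 percentage points higher from compound 2 to compound 4 (within the scatter) and a number 9 percentage points higher from compound 1 to compound 4 (within the scatter) as the steps. Compound 3 therefore stands alone among these four compounds, as a number 19.2 percentage points lower from compound 3 to compound 4 (beyond the scatter) also shows, and compound 2 shows that a carbonyl at this position does not by itself set it apart. Nothing in the data given explains this difference.

From the compounds shown here alone, it remains open whether a chloro on the benzyl ring of compound 4 would raise the number as it did on the benzoyl ring. Going by these compounds, how a small methyl, a longer alkyl chain or a chain ending in an amine would behave on this nitrogen is also open.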